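The source may hold more compounds than are shown below. What is called first, only, known or untested is meant among the compounds shown, and "the series" means these compounds.

Four compounds are compared here. Compound 1 `CC1=C(/C=C/C(=O)/C=C/c2cccc(F)c2)C(C)(C)CCC1` carries a fluoro on its aromatic ring, and in a functional assay on LNCaP cells (Homo sapiens) for cytotoxicity, read by MTT assay, with a stated time of 72 h (a lower number here means a stronger inhibitor, a higher number a weaker inhibitor), compound 1 gives 12900 nM. Compound 2 `CC1=C(/C=C/C(=O)/C=C/c2cccc([N+](=O)[O-])c2)C(C)(C)CCC1` differs from it by nitro in place of fluoro on an aromatic carbon, and in this assay compound 2 gives 2700 nM, so the measured step is a 4.8-fold lower number from compound 1 to compound 2 (0.68 log units; beyond the scatter). Compound 3 `CC1=C(/C=C/C(=O)/C=C/c2ccc(F)cc2)C(C)(C)CCC1O` has a different core; how its core differs from that of compound 1 is not broken down here. In this assay compound 3 gives 3900 nM, which lies close to the number for compound 2 and well away from that for compound 1. Compound 4 `CC1=C(/C=C/C(=O)/C=C/c2ccc([N+](=O)[O-])cc2)C(C)(C)CCC1O` has not yet been measured and differs from compound 3 by nitro in place of fluoro on an aromatic carbon. This is the same kind of change as that from compound 1 to compound 2, but not the same: in compound 4 the nitro is para to a large group, whereas in compound 2 it is meta to a large group. Among the compounds with values here, a step of the same direction, though somewhat smaller, is expected because the single measured example a 4.8-fold lower number from compound 1 to compound 2 (0.68 log units; beyond the scatter) came from a different core and placing, giving an estimated 3.3-fold lower number from compound 3 to compound 4 (0.51 log units; beyond the scatter). Compound 4 is therefore estimated at 1200 nM, expected to fall between 500 nM and 3000 nM.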

Compound 4, half-maximal inhibitory concentration: 4200 nM
Compound 4: middle estimate off by 3.5-fold (0.54 log units), on the low side, and the stated range ends below it.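

In this assay, putting nitro in place of fluoro on an aromatic carbon gives a 1.1-fold higher number from compound 3 to compound 4 (0.03 log units; within the scatter), so on this core the swap makes no difference that can be told from the scatter. Set beside the earlier step, the same swap does not carry over with the same size from one core to the other: the same change on two cores in this assay, a 4.8-fold lower number (0.68 log units; beyond the scatter) from compound 1 to compound 2 and a 1.1-fold higher number (0.03 log units; within the scatter) from compound 3 to compound 4, 5.1-fold (0.71 log units) apart, beyond the scatter of two such steps What this does not show is why, as the two pairs differ both in the core and in where the group sits on the aromatic ring, and one pair of each kind cannot separate these two differences.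

The compounds shown leave open what the swap does on the core of compound 1 when the group is para to a large group, which is the comparison that would tell core from placing. Also open, as far as these compounds go, is how an amine or a carboxylic acid on that same aromatic carbon would compare with fluoro and nitro on either core.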